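Phenyl for Benzyl at the Ring Nitrogen of Compound 2

The source may hold more compounds than are shown below. What is called first, only, known or untested is meant among the compounds shown, and "the series" means these compounds.

Three compounds share a dihydroxy acid side chain and a fluorophenyl group on a fused core, and all have been tested in an in vivo functional assay on the whole organism for inhibition of 3-hydroxy-3-methylglutaryl-coenzyme A reductase (Rattus norvegicus), at a dose of 2 mg/kg by the oral route; on this read-out lower numbers stand for a weaker effect and higher numbers for a stronger effect at the one dose given. Compound 1 `Cc1nn(C(C)(C)C)c2nc(C3CC3)c(/C=C/[C@@H](O)C[C@@H](O)CC(=O)O)c(-c3ccc(F)cc3)c12` gives 72.2% in this assay. Compound 2 `Cc1nn(Cc2ccccc2)c2nc(C(C)C)c(/C=C/[C@@H](O)C[C@@H](O)CC(=O)O)c(-c3ccc(F)cc3)c12` gives 45.1%, and compound 3 `CC(C)c1nc2cc(-c3ccccc3)nn2c(-c2ccc(F)cc2)c1/C=C/[C@@H](O)C[C@@H](O)CC(=O)O` gives 24.1%. Compound 2 therefore stands second highest of the three numbers: compound 1 lies above it and compound 3 below it, and both of these gaps are beyond the usual scatter of repeated measurements.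

The step followed here leads from compound 2 to compound 4 `Cc1nn(-c2ccccc2)c2nc(C(C)C)c(/C=C/[C@@H](O)C[C@@H](O)CC(=O)O)c(-c3ccc(F)cc3)c12`, which has not yet been measured in this assay. The change is phenyl in place of benzyl on an aromatic nitrogen. For the measured compounds named here, none of the measured pairs differs from one another in this single place, so no measured step shows what phenyl in place of benzyl on an aromatic nitrogen does here.

Going by the values given here, with no such step to rest on, the expectation for compound 4 in this assay is a change of no more than the scatter in either direction, so that the step of a number 0.1 percentage points lower from compound 2 to compound 4 (within the scatter) is estimated as small. Compound 4 is thus expected to give about 45%, within a range from 25% to 65%.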

Compound 4, a percentage reported as inhibition, in the whole organism at one dose (the size of the read-out at that dose, not a potency): 19.9%
Compound 4: the middle estimate sits 25.1 percentage points above what was measured, and the stated range ends above it.
By their numbers in this assay, from the lowest: compounds 4 and 3 (each within the scatter of the next); then compound 2; then compound 1.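

The earlier compounds shown here gave no reading of this position, and the new step shows that the group on the aromatic nitrogen of the five-membered aromatic ring matters in this assay: phenyl in place of benzyl gives a number 25.2 percentage points lower from compound 2 to compound 4 (beyond the scatter) and so takes away a substantial part of the effect at the one dose given. The size of this step stands out against the small difference between the two groups: benzyl has 7 heavy atoms and phenyl has 6, each group has one six-membered aromatic ring of carbon only, and neither has a hydrogen-bond donor, a hydrogen-bond acceptor or a net charge. Nothing available bears on why the effect falls with this exchange.

With a single step at this nitrogen, the compounds shown leave open whether a longer chain such as 2-phenylethyl would hold or raise the effect, and whether a pyridyl ring or a 4-fluorobenzyl group would behave like phenyl or like benzyl. They also leave open whether the same exchange would have a similar effect with the other groups on the core held differently.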